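Cytotoxicity limits across three substituents on the shared core

The compounds below may be only part of what the source reports. "The series", "measured", "known", "first", "only" and "open" are said of these compounds alone.

Measured so far in a functional assay on HepG2 cells (Homo sapiens) for cytotoxicity; a lower number here means that less compound is tolerated, a higher number that more compound is tolerated:
compound 1 `Nc1cn(COC(CO)CO)c(=O)[nH]c1=O` — > 432000 nM
compound 2 `Cc1cn(COC(CO)CO)c(=O)[nH]c1=O` — > 434000 nM
compound 3 `O=c1[nH]c(=O)n(COC(CO)CO)cc1CCO` — > 384000 nM

All three values are limits of this assay, not numbers. For compound 1 the reading of > 432000 nM is a limit. For compound 2 the reading of > 434000 nM is a limit. For compound 3 the reading of > 384000 nM is a limit. The steps between them are therefore unreadable: a step that the two limits leave unreadable from compound 1 to compound 2, a step that the two limits leave unreadable from compound 1 to compound 3 and a step that the two limits leave unreadable from compound 2 to compound 3. Compound 3 thus stands only at a limit, and the two other values stand at limits as well (the limit of > 384000 nM in this assay, at which 1 of the 3 values shown sits; (the limit of > 432000 nM in this assay, at which 1 of the 3 values shown sits); (the limit of > 434000 nM in this assay, at which 1 of the 3 values shown sits)).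

Compound 4 `O=c1[nH]c(=O)n(COC(CO)CO)cc1/C=C/Br` differs from compound 3 in one place: 2-bromoethenyl in place of 2-hydroxyethyl on an aromatic carbon. The measured steps that touch this position, the replacements from compound 1 to compound 3 and from compound 2 to compound 3, were both unreadable, so no size or direction of step can be read from the series for this assay. The expectation is therefore that compound 4 also sits at or near the limit, with the estimated step of an at least 1.2-fold lower number from compound 3 to compound 4 (0.10 log units; that floor lies within the scatter) carrying no readable direction. Compound 4 is estimated at 300000 nM, within 40000 nM to 500000 nM.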

Compound 4, half-maximal cytotoxic concentration: > 311000 nM
Compound 4: a limit, no number; the forecaster's own chance of this, stated with the estimate: 60%; at least 1.0-fold (0.01 log units) between middle value and limit.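

In this assay compound 4 gives > 311000 nM, which is a limit and not a number. The steps from compound 1, compound 2 and compound 3 to compound 4 therefore cannot be read. The compounds shown leave open what half-maximal cytotoxic concentration any of the four would reach, and whether the substituents differ at all.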